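Replacing a dimethylphenyl amide with a pyrimidine

The compounds below may be only part of what the source reports. "The series", "measured", "known", "first", "only" and "open" are said of these compounds alone.

Measured so far:
compound 1, `CSc1ccc2nc(C)cc(OCC(=O)Nc3cc(C)cc(C)c3)c2c1`, 3000 nM
compound 2, `COc1ccc2nc(C)cc(OCC(=O)Nc3cc(C)ccc3C)c2c1`, 45500 nM

Of the compounds shown here, two have been measured in a physicochemical assay for solubility, in phosphate buffer, measured as kinetic solubility, with a stated time of 1 h, at pH 7.4; on this read-out higher numbers stand for higher solubility and lower numbers for lower solubility. Compound 1 `CSc1ccc2nc(C)cc(OCC(=O)Nc3cc(C)cc(C)c3)c2c1` gives 3000 nM. Compound 2 `COc1ccc2nc(C)cc(OCC(=O)Nc3cc(C)ccc3C)c2c1` gives 45500 nM, the higher of the two numbers, and its gap to compound 1 lies beyond the usual scatter of repeated measurements. The two compounds differ in more than one place, so nothing further can be read from their pair.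

Compound 3 `COc1ccc2nc(C)cc(OCC(=O)Nc3ccncn3)c2c1` has not yet been measured in this assay. It differs from compound 2 in one place: pyrimidin-4-yl in place of 2,5-dimethylphenyl on an amide-type nitrogen. For the measured compounds named here, no measured pair here shows what such a change does, so the expectation rests on compound 2 alone and on the nature of the change. An increase in solubility is expected, since compound 2 already gives 45500 nM and the step of a 3.3-fold higher number from compound 2 to compound 3 (0.52 log units; beyond the scatter) is estimated to go upward by a clear amount, beyond the scatter. Compound 3 is therefore expected to give about 150000 nM, within a range from 40000 nM to 500000 nM.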

Compound 3, solubility: 27500 nM
Compound 3: the middle estimate sits 5.5-fold (0.74 log units) above what was measured; measured number below the stated range.
By their numbers in this assay, from the lowest: compound 1; then compounds 3 and 2 (each within the scatter of the next).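

In this assay, for the compounds shown here, putting pyrimidin-4-yl in place of 2,5-dimethylphenyl on the amide-type nitrogen gives a 1.7-fold lower number from compound 2 to compound 3 (0.22 log units; within the scatter), the first comparison here in which only one place differs. On this read-out, compound 2 and compound 3 cannot be told apart, even though a ring of carbon only, with 0 hydrogen-bond acceptors, has been exchanged for a ring with 2 hetero atoms and 2 hydrogen-bond acceptors. So at this position, such an exchange of aromatic rings need not move the number beyond the usual scatter of repeated measurements, and no measurement shown here offers an explanation for this result.

A single pair cannot show whether this holds for other groups at the same place, such as a pyridine ring, a morpholine or a phenyl ring carrying a carboxylic acid. From the compounds shown here alone, it also remains open whether pyrimidin-4-yl would give a similar result on the core of compound 1, which gives the lowest number of the three at 3000 nM in this assay.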